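Methylsulfanyl in Place of Methyl on the Nucleoside Series

This account rests on a few compounds, and the source may have more. Where it says the series, first, only, none or still open, it means among the compounds named here.

Two compounds of the series have been run in an ADME assay on MRC5 cells (Homo sapiens), read by MTT assay, with a stated time of 72 h; a lower number here means a stronger inhibitor, a higher number a weaker inhibitor. Compound 1 `CSc1ncnc2c1c(-c1ccccc1)cn2[C@@H]1O[C@H](CO)[C@@H](O)[C@H]1O` reaches only a limit: in this assay compound 1 gives > 100000 nM, which is a limit of the measurement and not a number. Within the data shown here, compound 2 `C#Cc1cn([C@@H]2O[C@H](CO)[C@@H](O)[C@H]2O)c2ncnc(C)c12` is the one compound with a measured number, and in this assay compound 2 gives 1440 nM. Among the measured compounds shown here, compound 1 and compound 2 differ in more than one place, so no single step connects them; the only limit seen is the limit of > 100000 nM in this assay, at which 1 of the 2 values shown sits, and it belongs to compound 1.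

Compound 3 `C#Cc1cn([C@@H]2O[C@H](CO)[C@@H](O)[C@H]2O)c2ncnc(SC)c12` is not yet measured. It differs from compound 2 in one place: methylsulfanyl in place of methyl on an aromatic carbon. For the measured compounds named here, no measured step carries this exact change, so the size of the step in this assay is open; a moderate weakening is expected, beyond the usual scatter but well short of the limit. The step from compound 2 to compound 3 is expected to be a 3.1-fold higher number from compound 2 to compound 3 (0.49 log units; beyond the scatter). The estimate for compound 3 is 4500 nM, within 900 nM to 30000 nM.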

Compound 3, half-maximal inhibitory concentration: > 100000 nM
Compound 3 ended at the assay's limit; the forecaster's own chance of this, stated with the estimate: 20%; middle value at least 22-fold (1.34 log units) away from the limit.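

Methylsulfanyl in place of methyl on this aromatic carbon, next to the ring nitrogen, is the first single change that can be read in the series, and in this assay it gives an at least 69-fold higher number from compound 2 to compound 3 (1.84 log units; beyond the scatter). In this assay compound 3 gives > 100000 nM, which is a limit of the assay and not a number. With the ethynyl group kept, this one exchange at this position is enough to move the series from a measured number to the limit, leaving compound 2 as the only compound with a number: the limit of > 100000 nM in this assay, at which 2 of the 3 values shown sit.

On these data alone, the step from compound 1 to compound 3 cannot be read, with limits on both sides, so ethynyl against phenyl stays open. Also open, as far as these compounds go, is whether an amine or a methoxy group on this carbon would keep a measured number.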